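The source may hold more compounds than are shown below. What is called first, only, known or untested is meant among the compounds shown, and "the series" means these compounds.

Working notes on the series. Among the measured compounds shown here, the three measured members share one core, seen in compound 1 `Cn1c(-c2ccc(NC(=O)CSc3nc4ccccc4o3)cc2)nc(-c2ccccc2)c1-c1ccccc1`, compound 2 `Cn1c(-c2ccc(NC(=O)CSc3nc4ccccc4s3)cc2)nc(-c2ccccc2)c1-c1ccccc1` and compound 3 `Cn1c(-c2ccc(NC(=O)CSC3=NCCS3)cc2)nc(-c2ccccc2)c1-c1ccccc1`; they differ only in the group carried on the sulfur. In a functional assay on HT-29 cells (Homo sapiens) for cytotoxicity, read by MTT assay, with a stated time of 24 h, tested at 6.4 ug/mL (on this read-out lower numbers stand for a weaker effect and higher numbers for a stronger effect at the one concentration tested), compound 1 gives 44.9%, compound 2 gives 36.8% and compound 3 gives 31%. Compound 2 stands second highest of the three, within the scatter of both others: a number 8.1 percentage points lower from compound 1 to compound 2 (within the scatter), and a number 5.8 percentage points lower from compound 2 to compound 3 (within the scatter). For the measured compounds named here, the only step beyond the scatter is a number 13.9 percentage points lower from compound 1 to compound 3 (beyond the scatter), and that one is modest.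

Compound 4 `CN(C)/C=C/N1CCN(CC(=O)Nc2ccc(-c3nc(-c4ccccc4)c(-c4ccccc4)n3C)cc2)CC1` steps outside this set of sulfur-borne rings: 4-(2-(dimethylamino)ethenyl)piperazin-1-yl in place of (1,3-benzothiazol-2-yl)sulfanyl on a saturated chain carbon bound to a carbonyl carbon. Going by the values given here, no measured step bears directly on such a change, since every measured step keeps the sulfur and swaps the ring on it. The closest guidance is that shrinking the group on the sulfur gave a number 5.8 percentage points lower from compound 2 to compound 3 (within the scatter) and a number 13.9 percentage points lower from compound 1 to compound 3 (beyond the scatter), so a downward step of modest size, or none beyond the scatter, is expected in this assay. Compound 4 is therefore estimated at 30%, between 15% and 47%, which would be an expected a number 6.8 percentage points lower from compound 2 to compound 4 (within the scatter).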

Compound 4, a percentage reported as activity, at one concentration (the size of the read-out at that concentration, not a potency): 12.2%
Compound 4: the middle estimate sits 17.8 percentage points above what was measured, outside the stated range (below it).
By their numbers in this assay, from the lowest: compound 4; then compounds 3, 2 and 1 (each within the scatter of the next, the first and the last beyond it).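

At the saturated chain carbon bound to a carbonyl carbon, 4-(2-(dimethylamino)ethenyl)piperazin-1-yl replaces the sulfur-linked ring as a whole, and in this assay the series shows a number 24.6 percentage points lower from compound 2 to compound 4 (beyond the scatter) and also a number 18.8 percentage points lower from compound 3 to compound 4 (beyond the scatter) as well as a number 32.7 percentage points lower from compound 1 to compound 4 (beyond the scatter). Among the compounds shown here, compound 4 therefore stands lowest of the four, and the earlier compounds, which all keep the sulfur, did not show that this position can carry a change of this reach with all three steps beyond the scatter. No measurement here gives a reason for this drop.

The compounds shown do not separate the loss of the sulfur from the entry of the piperazine ring or of its dimethylamino-bearing ethenyl arm. A plain piperazin-1-yl or a morpholin-4-yl group on the same carbon would be needed to tell these apart.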